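Swapping tert-butyl for chloro on a benzoate ester

This account rests on a few compounds, and the source may have more. Where it says the series, first, only, none or still open, it means among the compounds named here.

Measured so far:
Compound 1 `CN1CCC(OC(=O)c2ccc(C#N)cc2)CC1`: 1.65
Compound 2 `CN1CCC(OC(=O)c2ccc(Cl)c(Cl)c2)CC1`: 1.08
Compound 3 `CN1CCC(OC(=O)c2ccc(C(C)(C)C)cc2)CC1`: 1.13

These three compounds share one core and differ only in what sits on the aromatic ring. In a functional assay on the whole organism with Mus musculus as the target (a lower number here means a less potent compound, a higher number a more potent compound, by a factor of ten per unit of this negative logarithm), compound 3 gives 1.13, the second highest of the three numbers; compound 2 lies within the scatter of it, while compound 1 is the furthest away, as the step of a number 0.52 log units lower from compound 1 to compound 3 (beyond the scatter) shows.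

Compound 4 `CN1CCC(OC(=O)c2ccc(Cl)cc2)CC1` carries the change (chloro in place of tert-butyl on an aromatic carbon). For the measured compounds named here, no measured step involves chloro alone; the one known step, a number 0.52 log units lower from compound 1 to compound 3 (beyond the scatter), concerns cyano and does not bear directly on it. Compound 2, with two chloro groups, gives a value close to compound 3. Compound 4 is therefore expected at 1.2 (range 0.7 to 1.7), an expected step of a number 0.07 log units higher from compound 3 to compound 4 (within the scatter) within the scatter.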

Compound 4, logarithm of the reciprocal of the active concentration, log(1/C): 1.11
The estimate for compound 4 lay 0.09 log units above the measured number; the measured number falls inside the stated range.
By their numbers in this assay, from the lowest: compounds 2, 4 and 3 (each within the scatter of the next); then compound 1.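

In this assay, tert-butyl and chloro on this aromatic carbon cannot be told apart (a number 0.02 log units lower from compound 3 to compound 4 (within the scatter)), and hydrogen in place of the second chloro also leaves the number within the scatter (a number 0.03 log units higher from compound 2 to compound 4 (within the scatter)). Cyano alone stands apart from chloro, with a step beyond the scatter (a number 0.54 log units lower from compound 1 to compound 4 (beyond the scatter)). Nothing measured here explains why these groups behave as they do. As far as these compounds go, whether an amine or a carboxylic acid at this place would match cyano or chloro remains open.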